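Ester to Acid on the Orexin Receptor Binding Read-out

This account rests on a few compounds, and the source may have more. Where it says the series, first, only, none or still open, it means among the compounds named here.

Compound 1, `NC(=O)c1ccc2ccc(C(=O)c3ccccc3)c-2cc1`, 13.6%
Compound 2, `COC(=O)c1cccc2c(C(=O)c3ccccc3)cc(C(=O)c3ccc(C(Cl)(Cl)Cl)cc3)c-2c1`, 10.4%

In an assay on cells for displacement of a labelled ligand from Orexin/Hypocretin receptor type 1 (Homo sapiens), read by scintillation counting, with stated times of 10 min and 90 min, tested at 10 uM (a lower number here means less inhibition, a higher number more inhibition at the concentration tested (going by the name of the read-out)), compound 2 gives 10.4%, the lowest of the two numbers, while compound 1 gives 13.6%, which lies within the scatter of it. Compound 3, `O=C(O)c1cccc2c(C(=O)c3ccccc3)cc(C(=O)c3ccc(C(Cl)(Cl)Cl)cc3)c-2c1`, differs from compound 2 by hydrogen in place of methyl on an oxygen next to a carbonyl group, that is methoxycarbonyl to carboxy. Among the measured compounds shown here, no step between two measured compounds is known here, so the size of this change rests on expectation alone. With both measured compounds reading low, the step of a number 0.4 percentage points lower from compound 2 to compound 3 (within the scatter) is expected to stay within the scatter. Compound 3 is estimated at 10%, between 0% and 25%.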

Compound 3, a percentage reported as inhibition, at one concentration (the size of the read-out at that concentration, not a potency): 19.9%
Compound 3: the middle estimate sits 9.9 percentage points below what was measured, and the stated range covers the measured number.
By their numbers in this assay, from the lowest: compounds 2, 1 and 3 (each within the scatter of the next).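

In this assay, the exchange of methyl for hydrogen on an oxygen next to a carbonyl group gives a number 9.5 percentage points higher from compound 2 to compound 3 (within the scatter). Among the compounds shown here, this is the first step between compounds differing in one place, and it shows that methoxycarbonyl to carboxy does not move the read-out beyond the scatter on this core. Nothing measured here bears on the reason for this result. Still open, going by these compounds, is whether an ethyl ester or a hydroxymethyl group in this place would read the same, and whether methoxycarbonyl to carboxy would do so on another core.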